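Fluoro for bromo on the aromatic ring

The compounds below may be only part of what the source reports. "The series", "measured", "known", "first", "only" and "open" are said of these compounds alone.

Of the compounds shown here, two sharing one core have been measured in an assay on membranes from brain for binding affinity to adenosine receptor A1 (Rattus norvegicus), read by radioligand binding, tested at 20 uM; on this read-out lower numbers stand for less inhibition and higher numbers for more inhibition at the one concentration tested (going by the name of the read-out). Compound 1 `Cn1c(=O)[nH]c2c(cnn2C)c1=N` gives 6%. Compound 2 `Cn1c(=O)[nH]c2c(cnn2-c2cccc(Br)c2)c1=N` carries a six-membered aromatic ring of carbon only bearing a bromo group, and in this assay compound 2 gives 40%. This is the higher of the two numbers, and its gap to compound 1 lies beyond the usual scatter of such measurements.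

Compound 3 `Cn1c(=O)[nH]c2c(cnn2-c2cccc(F)c2)c1=N` has not yet been measured. It differs from compound 2 in one place: fluoro in place of bromo on an aromatic carbon. Among the compounds with values here, no measured pair shows this exchange, and the size of the step remains uncertain. The step from compound 2 to compound 3 is expected to be a modest fall, a number 15 percentage points lower from compound 2 to compound 3 (beyond the scatter), though a result within the scatter would not surprise. Compound 3 is therefore estimated to give 25%, with a likely range from 5% to 48%.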

Compound 3, a percentage reported as inhibition, at one concentration (the size of the read-out at that concentration, not a potency): 44%
Compound 3: the middle estimate sits 19 percentage points below what was measured; measured number inside the range.
By their numbers in this assay, from the lowest: compound 1; then compounds 2 and 3 (each within the scatter of the next).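

Exchanging bromo for fluoro on this aromatic carbon, meta to a large group, gives a number 4 percentage points higher from compound 2 to compound 3 (within the scatter) in this assay and so leaves the reading within the usual scatter. At the one concentration tested, this assay therefore does not tell these two halogens apart at this position, and the reading of compound 2 does not depend on bromo specifically. No measurement shown here offers an explanation for this match.

The compounds shown leave open whether this carbon needs a group at all, and what a hydrogen, a methoxy group or an amine would do there. They also leave open whether compound 2 and compound 3 would still match across a range of concentrations, since a single concentration gives no potency.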